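The source may report more compounds than this note shows. Statements on the series, on what has been measured and on what is new or still open speak of the compounds shown alone.

In a functional assay on A549 cells (Homo sapiens) for inhibition (a higher number here means a weaker inhibitor, a lower number a stronger inhibitor), compound 2 (`CN(C(=O)CC(CC(=O)NCCN1CCCC1)c1ccccc1)C1Cc2ccccc2C1`) gives > 100000 nM as its result, and this is a limit of the assay and not a number. Compound 3 (`CCN(CC)CCNC(=O)CC(CC(=O)N(C)C1Cc2ccccc2C1)c1ccccc1`) also yields only a limit, > 100000 nM as its result. In this assay compound 1 (`CCN(C(=O)CC(CC(=O)NCCN1CCCC1)c1ccc(Cl)cc1)C1Cc2ccccc2C1`) gives 22600 nM and is the only one of the three with a true number. Much of the picture therefore rests on the limit of > 100000 nM in this assay, at which 2 of the 3 values shown sit, and not on measured sizes.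

Compound 4 (`CCN(C(=O)CC(CC(=O)NCCN1CCCC1)c1ccccc1)C1Cc2ccccc2C1`) differs from compound 2 by one small change, methyl in place of hydrogen on a saturated chain carbon bound to an amide-type nitrogen (methyl in place of hydrogen on a saturated chain carbon bound to an amide-type nitrogen, which turns methyl to ethyl). For the measured compounds named here, the only measured step, a step that the two limits leave unreadable from compound 2 to compound 3 in this series, lies in a different place and has no readable size to lend. With no measured guide, a small shift towards stronger inhibition is expected, or none that can be read. The expected change is an at least 1.1-fold lower number from compound 2 to compound 4 (0.04 log units; that floor lies within the scatter) and remains only an estimate, since another limit is quite possible. For compound 4 the estimated value is 90000 nM with an expected range from 35000 nM to 200000 nM in this read-out.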

Compound 4, half-maximal inhibitory concentration: > 100000 nM
Compound 4: a limit, no number; the forecaster's own chance of this, stated with the estimate: 55%; at least 1.1-fold (0.04 log units) between middle value and limit.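

Compound 4 shares the ethyl group of compound 1 and lacks only its chloro, so the chloro can now be judged on its own: hydrogen in place of chloro on an aromatic carbon gives an at least 4.4-fold higher number from compound 1 to compound 4 (0.64 log units; beyond the scatter) in this assay, which lies beyond the usual scatter. Compound 4 gives only a limit, so ethyl without the chloro yields no readable number here. The steps that join two limits cannot be read, because both of their ends sit at a limit: the limit of > 100000 nM in this assay, at which 3 of the 4 values shown sit.

The compounds shown leave open whether a fluoro or a methoxy group on that aromatic carbon would do what chloro does. They also leave open whether chloro would still count with methyl or a longer propyl chain in place of the ethyl group.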